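The source may hold more compounds than are shown below. What is called first, only, known or untested is meant among the compounds shown, and "the series" means these compounds.

Going by the values given here, in a physicochemical assay for solubility, at pH 7.4 (on this read-out higher numbers stand for higher solubility and lower numbers for lower solubility), compound 1 `NS(=O)(=O)c1ccc(SCCCO)c(Cl)c1` gives 280 ug/mL, the lower of the two numbers available so far. Among the compounds with values here, the only other measured compound, compound 2 `NS(=O)(=O)c1ccc(S(=O)(=O)CCO)c(F)c1`, which also bears fluoro, gives 3300 ug/mL, a gap beyond the usual scatter of repeat measurements. Compound 2 differs from compound 1 in more than one place, and no single change can be read from that gap. Compound 3 `NS(=O)(=O)c1ccc(SCCCO)c(F)c1` keeps the core and the (3-hydroxypropyl)sulfanyl group of compound 1 and differs from it in one place: fluoro in place of chloro on an aromatic carbon. Within the data shown here, no measured pair isolates this swap, and the shared fluoro of compound 2 is only a thin hint of direction. A modest rise is expected, an estimated 2.0-fold higher number from compound 1 to compound 3 (0.29 log units; within the scatter), which may barely clear the scatter. For compound 3, the expected value in this assay is 550 ug/mL, within an estimated range of 280 ug/mL to 1100 ug/mL.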

Compound 3, solubility: 900 ug/mL
Beside the measured number, compound 3's estimate is 1.6-fold (0.21 log units) below it; measured number inside the range.
By their numbers in this assay, from the lowest: compound 1; then compound 3; then compound 2.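

In this assay, putting fluoro in place of chloro gives a 3.2-fold higher number from compound 1 to compound 3 (0.51 log units; beyond the scatter) with the rest of the molecule unchanged. Going by these compounds alone, this is the first pair that isolates a single change, and it shows that the number is sensitive to which of these two halogens sits on the aromatic carbon ortho to the (3-hydroxypropyl)sulfanyl group, even though the two groups match in their counts of heavy atoms, hydrogen-bond donors and hydrogen-bond acceptors. No measurement at hand accounts for this step.

The compounds shown leave open where a bromo, a methyl or a nitrile on this same carbon would fall relative to chloro and fluoro. They also leave open whether this swap would give a step of similar size with a longer chain or an amine in place of the (3-hydroxypropyl)sulfanyl group.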